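Swapping the amide aryl group: cyano out, dichloro in

This account rests on a few compounds, and the source may have more. Where it says the series, first, only, none or still open, it means among the compounds named here.

Measured compounds:
compound 1 `O=C(NCN1CCC(c2cccc[n+]2[O-])CC1)c1cnccc1Cl` — 1290 nM
compound 2 `N#Cc1cccc(C(=O)NCN2CCC(c3cccc[n+]3[O-])CC2)c1` — 840 nM
compound 3 `CCOc1cccc(C(=O)NCN2CCC(c3cccc[n+]3[O-])CC2)c1` — 324 nM

All three share one core and differ only in the aryl group attached to the carbonyl carbon of the amide. In a functional assay on HEK293 cells for agonist activity at D(4) dopamine receptor (Homo sapiens), read by FLIPR (on this read-out lower numbers stand for an effect already at smaller amounts and higher numbers for an effect only at larger amounts of compound), compound 2 gives 840 nM, which is the second highest of the three numbers; compound 1 sits nearest to it, and compound 3 furthest from it. The step of a 1.5-fold lower number from compound 1 to compound 2 (0.19 log units; within the scatter) shows that exchanging one aryl group for another can leave the number essentially unchanged, whereas the step of a 2.6-fold lower number from compound 2 to compound 3 (0.41 log units; beyond the scatter) shows that replacing the cyano group on the aromatic ring moved the number downward by a modest amount.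

Compound 4 `O=C(NCN1CCC(c2cccc[n+]2[O-])CC1)c1cc(Cl)cc(Cl)c1` has not been measured. It differs from compound 2 in this way: 3,5-dichlorophenyl in place of 3-cyanophenyl on a carbonyl carbon. Within the data shown here, since removing the cyano group in compound 3 gave 324 nM, a somewhat lower number than compound 2 is expected here as well, though the two chlorines are a different replacement and no measured step covers them directly. The expected step is a 1.7-fold lower number from compound 2 to compound 4 (0.23 log units; within the scatter), a modest change that may still fall near the scatter. Compound 4 is therefore estimated at 500 nM, with a range from 150 nM to 1600 nM.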

Compound 4, half-maximal effective concentration: 45 nM
Compound 4: middle estimate off by 11-fold (1.05 log units), on the high side, and the stated range ends above it.
By their numbers in this assay, from the lowest: compound 4; then compound 3; then compounds 2 and 1 (each within the scatter of the next).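

In this assay, among these compounds, the aryl group on the carbonyl carbon proves able to move the number much further than the earlier compounds showed, with 3,5-dichlorophenyl in place of 3-cyanophenyl giving a large drop (a 19-fold lower number from compound 2 to compound 4 (1.27 log units; beyond the scatter)) and the same group in place of 4-chloropyridin-3-yl giving a similarly large one (a 29-fold lower number from compound 1 to compound 4 (1.46 log units; beyond the scatter)). The first of these swaps removes a nitrile, with its triple bond and hydrogen-bond acceptor, and brings in two chlorines, so this single pair cannot show which of those differences matters. Nothing available explains the size of the drop.

On these data alone, it remains open whether a phenyl ring with a single chlorine would give a similar number. Two methyl groups or two bromines in place of the chlorines are also untested here.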